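Adding a Hydroxyl to the Methoxyphenyl Hydrazone

A few compounds are considered here, and "the series" means these few. Any claim that something is new, unique, unknown or untested is made for them only; others in the source may bear on it.

The series shares one core, carried by compound 1 `O=C(CSc1nnc(-c2ccncc2)o1)N/N=C/c1ccccc1`, compound 2 `COc1ccc(/C=N/NC(=O)CSc2nnc(-c3ccncc3)o2)cc1` and compound 3 `COc1cccc(/C=N/NC(=O)CSc2nnc(-c3ccncc3)o2)c1`. In a functional assay on BGC-823 cells (Homo sapiens) for cytotoxicity, read by MTT assay, with a stated time of 48 h (a higher number here means a weaker inhibitor, a lower number a stronger inhibitor), compound 1 gives 22100 nM, compound 2 gives 19800 nM and compound 3 gives 15800 nM. Compound 2 thus stands second highest of the three numbers, with a 1.1-fold lower number from compound 1 to compound 2 (0.05 log units; within the scatter) and a 1.3-fold lower number from compound 2 to compound 3 (0.10 log units; within the scatter) both within the scatter, so the three cannot be ordered.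

Compound 4 `COc1cc(/C=N/NC(=O)CSc2nnc(-c3ccncc3)o2)ccc1O` differs from compound 2 by 4-hydroxy-3-methoxyphenyl in place of 4-methoxyphenyl on a carbon with a double bond to nitrogen. Among the measured compounds shown here, the steps that bear on this are a 1.1-fold lower number from compound 1 to compound 2 (0.05 log units; within the scatter) and a 1.4-fold lower number from compound 1 to compound 3 (0.15 log units; within the scatter), each a methoxy in place of hydrogen on an aromatic carbon, and neither moved the number beyond the scatter. Adding a second oxygen substituent on the same ring has no closer precedent here, so compound 4 is expected to remain close to compound 2, with a 1.1-fold lower number from compound 2 to compound 4 (0.04 log units; within the scatter) as the estimated step. Compound 4 is therefore estimated at 18000 nM in this assay, within 9000 nM to 36000 nM.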

Compound 4, half-maximal inhibitory concentration: 4320 nM
Compound 4: the middle estimate sits 4.2-fold (0.62 log units) above what was measured; measured number outside the range, below it.
By their numbers in this assay, from the lowest: compound 4; then compounds 3, 2 and 1 (each within the scatter of the next).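

In this assay the methoxy steps had left the number within the scatter, whereas this position on the carbon with a double bond to nitrogen now shows a change beyond it: 4-hydroxy-3-methoxyphenyl gives a 4.6-fold lower number from compound 2 to compound 4 (0.66 log units; beyond the scatter) against 4-methoxyphenyl and a 5.1-fold lower number from compound 1 to compound 4 (0.71 log units; beyond the scatter) against phenyl. Among the compounds shown here, the added hydroxy as the single change gives a 3.7-fold lower number from compound 3 to compound 4 (0.56 log units; beyond the scatter) and so ties the step to the hydroxy added to the methoxyphenyl ring, not to the methoxy alone. No measurement here gives a reason for this step.

On these data alone, whether the hydroxy would give a similar step without the methoxy stays open. So does whether an amine or a carboxylic acid in place of the hydroxy would do the same.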